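Replacing the amino-bearing chain on sulfur in compound 2

This account rests on a few compounds, and the source may have more. Where it says the series, first, only, none or still open, it means among the compounds named here.

Among the compounds with values here, in a functional assay on HT cells (Homo sapiens) for antiproliferative activity, read by fluorescence, with a stated time of 72 h (a higher number here means a weaker inhibitor of growth, a lower number a stronger inhibitor of growth), compound 2 (`CC(C)c1n[nH]c2c(NCc3ccc(-c4ccccn4)cc3)nc(SCC(O)CN)nc12`) gives 55 nM and holds the lower of the two numbers measured so far. Within the data shown here, the only other measured compound has trifluoromethyl in place of aminomethyl: compound 1 (`CC(C)c1n[nH]c2c(NCc3ccc(-c4ccccn4)cc3)nc(SCC(O)C(F)(F)F)nc12`) gives 690 nM in that series.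

The next compound, compound 3 (`CC(C)c1n[nH]c2c(NCc3ccc(-c4ccccn4)cc3)nc(SC(CO)C(C)C)nc12`), keeps the shared core and differs only on the sulfur, where 1-(hydroxymethyl)-2-methylpropyl stands in place of 3-amino-2-hydroxypropyl: 1-(hydroxymethyl)-2-methylpropyl in place of 3-amino-2-hydroxypropyl on a sulfur in all.

Among the measured compounds shown here, one measured step bears on this change: a 13-fold lower number from compound 1 to compound 2 (1.10 log units; beyond the scatter) on the same chain. That large step accompanied the arrival of the amino group, and compound 3 has no amino group, as compound 1 has none. For the measured compounds named here, a rise in the number is therefore expected, though probably a smaller one than that step, and no measured compound carries the entering group, so the size remains uncertain. The expected change is a 3.6-fold higher number from compound 2 to compound 3 (0.56 log units; beyond the scatter) in this estimate. For compound 3 the estimated value is 200 nM with an expected range from 60 nM to 700 nM in this assay once it is measured.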

Compound 3, concentration for 50% growth inhibition: 980 nM
Compound 3: middle estimate off by 4.9-fold (0.69 log units), on the low side, and the stated range ends below it.
By their numbers in this assay, from the lowest: compound 2; then compounds 1 and 3 (each within the scatter of the next).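

In this assay, the new chain gives an 18-fold higher number from compound 2 to compound 3 (1.25 log units; beyond the scatter) on this sulfur, so a hydroxyl-bearing chain alone does not keep the low number of compound 2. Two chains without an amino group can now be compared, with a 1.4-fold higher number from compound 1 to compound 3 (0.15 log units; within the scatter) between them, and trifluoromethyl on the earlier chain and the branched 1-(hydroxymethyl)-2-methylpropyl cannot be told apart here. Among the three compounds, only the one with 3-amino-2-hydroxypropyl stands apart and none goes against that reading, but this change also alters the shape of the chain, so the amino group cannot be singled out as the group responsible. No measurement bearing on why these chains differ is available.

The compounds shown leave open whether the amino group by itself goes with the low number, or only the amino group together with the hydroxyl on the same chain. A 3-aminopropyl chain, a chain ending in a dimethylamine, a branched chain carrying an amine, or a carboxylic acid on the same sulfur would each bear on that question.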